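A few compounds are considered here, and "the series" means these few. Any claim that something is new, unique, unknown or untested is made for them only; others in the source may bear on it.

Compound 1 `COc1ccc(Nc2ncc3cc(S(=O)(=O)c4ccc(C)cc4)c(=O)n(C)c3n2)cc1`: 75000 nM
Compound 2 `Cn1c(=O)c(C(=O)Nc2ccc(F)cc2F)cc2cnc(Nc3ccc4[nH]ccc4c3)nc21`: 5000 nM
Compound 3 `CCCn1c(=O)c(S(=O)(=O)c2ccc(F)cc2F)cc2cnc(Nc3ccc4[nH]ccc4c3)nc21`: 1000 nM

In a functional assay on K562 cells (Homo sapiens) for inhibition, read by trypan blue exclusion, with a stated time of 72 h (on this read-out higher numbers stand for weaker inhibition and lower numbers for stronger inhibition), compound 1 gives the highest of the three numbers, 75000 nM, which makes it the weakest inhibitor here. Compound 2 and compound 3 both lie beyond the scatter from it.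

Compound 4 `COc1ccc(Nc2ncc3cc(S(=O)(=O)c4ccc(Cl)cc4)c(=O)n(C)c3n2)cc1` keeps the core of compound 1 but has chloro in place of methyl on an aromatic carbon, turning 4-methylphenyl into 4-chlorophenyl (chloro in place of methyl on an aromatic carbon). Within the data shown here, no measured pair isolates this change, since compound 2 and compound 3 differ from compound 1 in several places. One heavy atom replaces one heavy atom, so no step beyond the scatter is expected in this assay. The expected 1.3-fold lower number from compound 1 to compound 4 (0.10 log units; within the scatter) is small. For compound 4 the estimate is 60000 nM, with an expected range of 20000 nM to 150000 nM.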

Compound 4, half-maximal inhibitory concentration: 15000 nM
Beside the measured number, compound 4's estimate is 4.0-fold (0.60 log units) above it; the measured number lies below the stated range.
By their numbers in this assay, from the lowest: compound 3; then compound 2; then compound 4; then compound 1.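

Changing (4-methylphenyl)sulfonyl to (4-chlorophenyl)sulfonyl gives, in this assay, a 5.0-fold lower number from compound 1 to compound 4 (0.70 log units; beyond the scatter). Among these compounds, this is the first pair here that differs in one place, and it shows that replacing one atom on this aromatic carbon, para to a large group, can move the number beyond the usual scatter. Nothing measured here explains the size or direction of this step.

The compounds shown leave open what bromo, trifluoromethyl or an amine would do at this same place. They also leave open whether chloro gives a similar step when the rest of the molecule differs.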